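The source may report more compounds than this note shows. Statements on the series, on what has been measured and on what is new or still open speak of the compounds shown alone.

Compound 1 `C#Cc1cn([C@@H]2O[C@H](CO)[C@@H](O)[C@H]2O)c2ncnc(OC)c12`: 3490 nM
Compound 2 `CSc1ncnc2c1c(-c1ccoc1)cn2[C@@H]1O[C@H](CO)[C@@H](O)[C@H]1O`: > 20000 nM, a limit
Compound 3 `CNc1ncnc2c1c(-c1ccoc1)cn2[C@@H]1O[C@H](CO)[C@@H](O)[C@H]1O`: > 20000 nM, a limit

In a functional assay on CEM-DNR-bulk cells (Homo sapiens), read by MTT assay, with a stated time of 72 h (a lower number here means a stronger inhibitor, a higher number a weaker inhibitor), compound 3 has only a limit, > 20000 nM. The same limit is shared with compound 2: the limit of > 20000 nM in this assay, at which 2 of the 3 values shown sit. Within the data shown here, the one measured step, a step that the two limits leave unreadable from compound 2 to compound 3, has no readable size and changes a different group. Compound 4 `CNc1ncnc2c1c(-c1cc3ccccc3o1)cn2[C@@H]1O[C@H](CO)[C@@H](O)[C@H]1O` carries 1-benzofuran-2-yl in place of furan-3-yl on an aromatic carbon. Among the measured compounds shown here, no measured step covers this exchange, so no size or direction can be carried over, and in this assay little change is expected. The expected step is a number no higher from compound 3 to compound 4 (the limit leaves the size open). For compound 4 the estimate is 20000 nM, with an expected range of 6000 nM to 50000 nM.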

Compound 4, half-maximal inhibitory concentration: > 20000 nM
Compound 4: only a limit was reported (the forecaster's own chance of this, stated with the estimate: 70%); the middle value lies on the limit itself.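

Compound 3 and compound 4 give no readable step in this assay, as both stand only as limits: the limit of > 20000 nM in this assay, at which 3 of the 4 values shown sit. Left open is whether 1-benzofuran-2-yl and furan-3-yl differ at all in this assay.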